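The source may report more compounds than this note shows. Statements on the series, on what has been measured and on what is new or still open speak of the compounds shown alone.

Measured compounds:
compound 1 `CCCCCCCCn1cc(COC2(C(F)(F)F)Oc3ccccc3C=C2C(=O)OCC)nn1` — > 150000 nM
compound 2 `O=C(O)C1=Cc2ccccc2OC1(OCc1cc(-c2ccc3ccccc3c2)no1)C(F)(F)F` — > 150000 nM

Both values come from a functional assay on A549 cells (Homo sapiens) for inhibition, read by MTT assay, with a stated time of 24 h; a higher number here means a weaker inhibitor, a lower number a stronger inhibitor. For compound 1 the value is a limit of the assay. For compound 2 the value is likewise a limit. Compound 1 therefore stands where the only other measured compound stands, as shown by the limit of > 150000 nM in this assay, at which 2 of the 2 values shown sit; no step between measured compounds is available, and the two values show only that neither compound gave a number.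

Compound 3 `CCOC(=O)C1=Cc2ccccc2OC1(OCc1cn(-c2cccc(C(F)(F)F)c2)nn1)C(F)(F)F` has not been measured. It differs from compound 1 by 3-(trifluoromethyl)phenyl in place of octyl on an aromatic nitrogen. Going by the values given here, no measured pair bears on this change. In this assay compound 3 is expected at 150000 nM, within a range of 40000 nM to 400000 nM, and most probably reported again only as a limit. The step expected is a number no higher from compound 1 to compound 3 (the limit leaves the size open), none beyond the scatter.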

Compound 3, half-maximal inhibitory concentration: > 150000 nM
Compound 3 ended at the assay's limit; the forecaster's own chance of this, stated with the estimate: 75%; the middle value lies on the limit itself.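

Compound 1 and compound 3 both sit at a limit of the assay, so no step can be read for 3-(trifluoromethyl)phenyl in place of octyl on an aromatic nitrogen: the limit of > 150000 nM in this assay, at which 3 of the 3 values shown sit.

The compounds shown leave open which change on this series, if any, would give a number rather than a limit.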